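This account rests on a few compounds, and the source may have more. Where it says the series, first, only, none or still open, it means among the compounds named here.

Compound 1 `CN1C[C@H](C(=O)Nc2cccc(Cl)c2)[C@@H](c2ccc(/C=C/C(=O)Nc3ccccc3N)cc2)C1` gives 58 mL/min/kg in an in vitro ADME assay on microsomes from liver (Mus musculus) for pharmacokinetics, read by LC-MS, with a stated time of 10 min, tested at 1 uM; on this read-out higher numbers stand for fast clearance and lower numbers for slow clearance.
Compound 2 `CN1C[C@H](C(=O)Nc2ccc(F)c(F)c2)[C@@H](c2ccc(/C=C/C(=O)Nc3ccccc3N)cc2)C1` gives 46 mL/min/kg.
Compound 3 `CN1C[C@H](C(=O)Nc2cccnc2)[C@@H](c2ccc(/C=C/C(=O)Nc3ccccc3N)cc2)C1` gives 41 mL/min/kg.

Compound 2 stands second highest of these three numbers, with compound 3 nearest through a 1.1-fold lower number from compound 2 to compound 3 (0.05 log units; within the scatter) and compound 1 furthest through a 1.3-fold lower number from compound 1 to compound 2 (0.10 log units; within the scatter), so the three sit within the scatter of one another. Compound 4 `CN1C[C@H](C(=O)N2CCCCC2)[C@@H](c2ccc(/C=C/C(=O)Nc3ccccc3N)cc2)C1` differs from compound 2 by piperidin-1-yl in place of (3,4-difluorophenyl)amino on a carbonyl carbon. The measured steps each exchange one aromatic group for another on the amide-type nitrogen, and a 1.4-fold lower number from compound 1 to compound 3 (0.15 log units; within the scatter) is as small as the others. None of them replaces the amino group itself with piperidin-1-yl, so they bear on this step only loosely. A step of a 1.0-fold lower number from compound 2 to compound 4 (0.01 log units; within the scatter) is therefore expected, without a direction beyond the scatter. Compound 4 is estimated at 45 mL/min/kg, between 22 mL/min/kg and 90 mL/min/kg.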

Compound 4, clearance: 42 mL/min/kg
The estimate for compound 4 lay 1.1-fold (0.03 log units) above the measured number; measured number inside the range.
By their numbers in this assay, from the lowest: compounds 3, 4, 2 and 1 (each within the scatter of the next).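

For the compounds shown here, the earlier compounds exchanged only one aromatic group for another on the amide-type nitrogen, whereas compound 4 replaces the whole arylamino group with piperidin-1-yl, so that the amide hydrogen and the aromatic ring both go. Even this larger change leaves mouse microsomal clearance within the scatter of all three earlier compounds (a 1.1-fold lower number from compound 2 to compound 4 (0.04 log units; within the scatter); a 1.0-fold higher number from compound 3 to compound 4 (0.01 log units; within the scatter); a 1.4-fold lower number from compound 1 to compound 4 (0.14 log units; within the scatter)). Nothing available explains why these clearances stay so close. The compounds shown leave open whether a morpholin-4-yl or dimethylamino group on this carbonyl carbon would also stay within the scatter. They also leave open whether a carboxylic acid on the carbonyl-bearing substituent would do so.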